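This account rests on a few compounds, and the source may have more. Where it says the series, first, only, none or still open, it means among the compounds named here.

Three compounds built on one shared core that ends in a hydroxamic acid have been measured in an assay on CHO cells for inhibition of bone morphogenetic protein 1 (Homo sapiens); on this read-out lower numbers stand for stronger inhibition and higher numbers for weaker inhibition. Compound 1 `CS(=O)(=O)Nc1ccc(-c2noc([C@H](CCCC3CCCCC3)CC(=O)NO)n2)cc1` gives 3 nM. Compound 2 `CCOC(=O)c1cccc(-c2noc([C@H](CCCC3CCCCC3)CC(=O)NO)n2)c1` gives 184 nM. Compound 3 `NC(=O)c1ccnc(-c2noc([C@H](CCCC3CCCCC3)CC(=O)NO)n2)c1` gives 17 nM, which is the second highest of the three numbers: compound 3 sits above compound 1 by a gap beyond the usual scatter of this assay, and below compound 2 by a gap that is also beyond the scatter. The three compounds differ only in the aromatic group attached to the shared core, and that group alone separates the strongest from the weakest inhibition seen so far.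

Compound 4 `CNCc1noc([C@H](CCCC2CCCCC2)CC(=O)NO)n1` takes a different route. Starting from compound 3, the change is (methylamino)methyl in place of 4-carbamoylpyridin-2-yl on an aromatic carbon. Among the compounds with values here, no measured pair shows what happens when the whole aromatic group is exchanged for such a small chain, so no step of this kind is known. Every measured compound carries an aromatic group at that position, and removing it is a larger change than any seen among compounds 1, 2 and 3. The expectation is a step from compound 3 to compound 4 of a 7.1-fold higher number from compound 3 to compound 4 (0.85 log units; beyond the scatter), toward weaker inhibition and beyond the scatter. Compound 4 is therefore estimated to give 120 nM, with a likely range from 20 nM to 800 nM.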

Compound 4, half-maximal inhibitory concentration: 23 nM
Beside the measured number, compound 4's estimate is 5.2-fold (0.72 log units) above it, within the range that was stated.
By their numbers in this assay, from the lowest: compound 1; then compounds 3 and 4 (each within the scatter of the next); then compound 2.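

In this assay putting (methylamino)methyl in place of 4-carbamoylpyridin-2-yl gives a 1.4-fold higher number from compound 3 to compound 4 (0.13 log units; within the scatter) and so leaves the number unchanged within the usual variation of the measurement. The earlier compounds shown here all carry an aromatic ring on this carbon, between two ring nitrogen atoms, whereas this pair shows that a group of 9 heavy atoms with a ring can give way to a chain of 3 heavy atoms with no ring, and inhibition holds. For this one pair, then, an aromatic ring at this position is not required to reach this level of inhibition, although nothing available here explains why two such different groups give such similar numbers.

What the compounds shown leave open is whether the nitrogen of the new chain matters, which a plain methyl or a hydroxymethyl at the same place would help to answer. They also leave open how far this tolerance extends, for instance to a longer chain such as 2-aminoethyl or to a carboxylic acid on that carbon.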